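This account rests on a few compounds, and the source may have more. Where it says the series, first, only, none or still open, it means among the compounds named here.

Measured compounds:
- compound 1 `COc1cc(-c2cc(/C=C/C(=O)c3ccc(Cl)c(Cl)c3)[nH]n2)cc(OC)c1OC`: 94%
- compound 2 `COc1ccc(-c2cc(/C=C/C(=O)c3ccc(N)cc3)[nH]n2)cc1OC`: 103%
- compound 3 `COc1ccc(-c2cc(/C=C/C(=O)c3cc(OC)c(OC)c(OC)c3)[nH]n2)cc1OC`: 100%

All three were run in a functional assay on SK-MEL-2 cells (Homo sapiens) for cytotoxicity, read by sulforhodamine B assay, with a stated time of 48 h, tested at 0.01 uM; a higher number here means a weaker effect of the compound at the concentration tested, a lower number a stronger effect. Compound 1 gives 94%, compound 2 gives 103% and compound 3 gives 100%. Compound 1 holds the lowest of the three numbers, but its gaps to compound 3 and to compound 2 are both within the usual scatter, so at this concentration the three cannot be told apart, and none shows a clear effect.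

The next compound is compound 4 `COc1ccc(C(=O)/C=C/c2cc(-c3cc(OC)c(OC)c(OC)c3)n[nH]2)cc1OC`, which differs from compound 1 in one place: 3,4-dimethoxyphenyl in place of 3,4-dichlorophenyl on a carbonyl carbon. The shared core and the chain carrying the carbonyl are kept.

Within the data shown here, nothing among the measured compounds gives a step for such a change, since no two of them differ in one place. Given that compound 3, which also carries only methoxy substituents, gives 100%, no step beyond the scatter in this assay is expected here, in either direction. The expected step of a number 4 percentage points higher from compound 1 to compound 4 (within the scatter) is small. For compound 4 the estimate in this assay is 98%, with a range from 86% to 110%.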

Compound 4, a percentage reported as activity, at one concentration (the size of the read-out at that concentration, not a potency): 86%
For compound 4 the middle estimate is 12 percentage points above the measured one, within the range that was stated.
By their numbers in this assay, from the lowest: compounds 4, 1, 3 and 2 (each within the scatter of the next, the first and the last beyond it).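

Among these compounds, this is the first one-place step: in this assay, 3,4-dimethoxyphenyl in place of 3,4-dichlorophenyl on a carbonyl carbon gives a number 8 percentage points lower from compound 1 to compound 4 (within the scatter) and so leaves no readable difference at the concentration tested. At this position, then, the two groups cannot be told apart, even though the entering group brings two hydrogen-bond acceptors and the leaving group none. No measurement on either group bears on this result.

On these data alone, whether a carboxylic acid or a trifluoromethyl group in place of 3,4-dichlorophenyl on the same carbonyl carbon would give a step beyond the scatter remains open. Also open, as far as these compounds go, is whether compound 1 and compound 4 would separate at any other concentration.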